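This account rests on a few compounds, and the source may have more. Where it says the series, first, only, none or still open, it means among the compounds named here.

Three close relatives built on one shared core have been examined in a functional assay on BGC-823 cells (Homo sapiens) for cytotoxicity, read by MTT assay, with a stated time of 24 h; on this read-out lower numbers stand for stronger inhibition and higher numbers for weaker inhibition. Compound 1 `COC(=O)[C@@H](CC(C)C)NC(=O)Cn1cc(C2=C(c3c[nH]c4ccccc34)C(=O)N(C)C2=O)c2ccccc21` gives 45500 nM. Compound 2 `COC(=O)C[C@@H](NC(=O)Cn1cc(C2=C(c3c[nH]c4ccccc34)C(=O)N(C)C2=O)c2ccccc21)C(=O)OC` gives 24600 nM, and compound 3 `COC(=O)[C@@H](CO)NC(=O)Cn1cc(C2=C(c3c[nH]c4ccccc34)C(=O)N(C)C2=O)c2ccccc21` gives 28900 nM. The gaps among them are small: a 1.8-fold lower number from compound 1 to compound 2 (0.27 log units; within the scatter), a 1.6-fold lower number from compound 1 to compound 3 (0.20 log units; within the scatter) and a 1.2-fold higher number from compound 2 to compound 3 (0.07 log units; within the scatter). Compound 3 thus holds the second highest number of the measured set, closest to compound 2 and furthest from compound 1, yet separated from neither by more than the usual scatter of repeated measurements.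

Compound 4 `COC(=O)[C@H](NC(=O)Cn1cc(C2=C(c3c[nH]c4ccccc34)C(=O)N(C)C2=O)c2ccccc21)C(C)C` has not yet been measured. It differs from compound 3 in one place: isopropyl in place of hydroxymethyl on a saturated chain carbon bound to an amide-type nitrogen and a carbonyl carbon. Going by the values given here, the comparison that bears most directly on this change is the one between compound 1 and compound 3, where hydroxy stood in place of isopropyl on a saturated chain carbon and where a 1.6-fold lower number from compound 1 to compound 3 (0.20 log units; within the scatter) was seen; the present change swaps a hydroxy-bearing group back for a branched hydrocarbon group. Because a 1.8-fold lower number from compound 1 to compound 2 (0.27 log units; within the scatter) and every other measured step stayed within the scatter, no step beyond the scatter is expected for compound 4, estimated as a 1.2-fold higher number from compound 3 to compound 4 (0.08 log units; within the scatter). Compound 4 is therefore expected to give about 35000 nM, within a range from 17000 nM to 70000 nM.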

Compound 4, half-maximal inhibitory concentration: 48200 nM
Compound 4: the middle estimate sits 1.4-fold (0.14 log units) below what was measured; measured number inside the range.
By their numbers in this assay, from the lowest: compounds 2, 3, 1 and 4 (each within the scatter of the next).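

In this assay, isopropyl in place of hydroxymethyl on the saturated chain carbon bound to an amide-type nitrogen and a carbonyl carbon gives a 1.7-fold higher number from compound 3 to compound 4 (0.22 log units; within the scatter) and so does not separate the two groups, even though only hydroxymethyl carries a hydrogen-bond donor. The two other new comparisons at this carbon lead to the same reading: isopropyl in place of (methoxycarbonyl)methyl gives a 2.0-fold higher number from compound 2 to compound 4 (0.29 log units; within the scatter) and isopropyl in place of isobutyl gives a 1.1-fold higher number from compound 1 to compound 4 (0.03 log units; within the scatter), so all four groups shown remain indistinguishable in this assay. No other kind of measurement is available here to explain these numbers.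

The groups shown at this carbon are limited to hydrocarbon chains, a hydroxymethyl and a methyl ester side chain, so it remains open whether an amine, a carboxylic acid or a benzyl group there would give a step beyond the scatter. All four compounds also keep the methyl ester on the chain, which leaves open what a free carboxylic acid or a simple amide at that end would do to the number.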